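A few compounds are considered here, and "the series" means these few. Any claim that something is new, unique, unknown or untested is made for them only; others in the source may bear on it.

Three ureas share one core and differ only in small outer groups. In an ADME assay on the whole organism with Oryza sativa as the target, tested at 0.1 uM (a higher number here means a weaker effect of the compound at the concentration tested, a lower number a stronger effect), compound 1 `CC(C)c1ccc(NC(=O)N[C@H](C)c2ccccc2)cc1` gives 99%, compound 2 `CC(C)c1ccc(NC(=O)N[C@@H](C)c2ccccc2)cc1` gives 98%, and compound 3 `CCCc1ccc(NC(=O)N[C@H](C)c2ccccc2)cc1` gives 33%. Compound 2 therefore stands second highest of the three, next to compound 1 and far from compound 3. The step of a number 1 percentage points lower from compound 1 to compound 2 (within the scatter) changes almost nothing, which fits because of the fact that compounds 1 and 2 differ only in the configuration as drawn. The step of a number 66 percentage points lower from compound 1 to compound 3 (beyond the scatter) is large, with propyl in place of isopropyl on an aromatic carbon.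

Compound 4 `C[C@H](NC(=O)Nc1ccc(C(C)(C)C)cc1)c1ccccc1` has not yet been measured. It differs from compound 2 by methyl in place of hydrogen on a saturated chain carbon bound to an aromatic carbon and two saturated chain carbons. Within the data shown here, no measured step adds a methyl at this spot, so only the two steps above can guide an expectation: one shows that the configuration at the chain carbon leaves the read-out unchanged, the other shows a large drop when isopropyl is replaced by propyl. Since compound 4 keeps and extends the branched group rather than removing it, the expected step is a number 4 percentage points lower from compound 2 to compound 4 (within the scatter), within the scatter. Compound 4 is estimated at 94%, with a range from 70% to 100%.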

Compound 4, a percentage reported as activity, at one concentration (the size of the read-out at that concentration, not a potency): 100%
Compound 4: middle estimate off by 6 percentage points, on the low side; low and high end bracket the measured number.
By their numbers in this assay, from the lowest: compound 3; then compounds 2, 1 and 4 (each within the scatter of the next).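

In this assay, methyl in place of hydrogen on a saturated chain carbon bound to an aromatic carbon and two saturated chain carbons, which turns isopropyl into tert-butyl, gives a number 2 percentage points higher from compound 2 to compound 4 (within the scatter), so more branching in this group leaves the read-out where it stood. Until now this group had shown only that a change can move the number far, with propyl in place of isopropyl; this step shows that a change here can also leave it unmoved, so the effect depends on which group enters. The data shown offer no explanation for this result.

As far as these compounds go, whether a longer chain such as butyl would behave like propyl remains open. From the compounds shown here alone, how a cyclopropyl or methoxy group on that aromatic carbon would read is also open.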